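3-chlorobenzyl to 2-chlorobenzyl in compound 1

A few compounds are considered here, and "the series" means these few. Any claim that something is new, unique, unknown or untested is made for them only; others in the source may bear on it.

Values measured in a functional assay on A549 cells (Homo sapiens) for cytotoxicity, read by MTT assay, with a stated time of 72 h (a lower number here means a stronger inhibitor, a higher number a weaker inhibitor), follow.
- compound 1 `CC1CCN(Cc2ccc3nc(NC(=O)N/N=C/c4cn(Cc5cccc(Cl)c5)c5ccccc45)sc3c2)CC1` gives 2810 nM
- compound 2 `CN(C)Cc1ccc2nc(NC(=O)N/N=C3\C(=O)Nc4ccc(Cl)cc43)sc2c1` gives 3180 nM
- compound 3 `CCN(CC)Cc1ccc2nc(NC(=O)N/N=C/c3cn(Cc4cccc(Cl)c4)c4ccccc34)sc2c1` gives 2410 nM

Compound 1 stands within the scatter of both compound 2 and compound 3, so these values give no order. Compound 4 `CC1CCN(Cc2ccc3nc(NC(=O)N/N=C/c4cn(Cc5ccccc5Cl)c5ccccc45)sc3c2)CC1` is still unmeasured in this assay and differs from compound 1 as follows: 2-chlorophenyl in place of 3-chlorophenyl on a saturated chain carbon bound to an aromatic nitrogen with 2-chlorophenyl in place of 3-chlorophenyl on a saturated chain carbon bound to an aromatic nitrogen. For the measured compounds named here, the one measured step, a 1.2-fold lower number from compound 1 to compound 3 (0.07 log units; within the scatter) for diethylamino in place of 4-methylpiperidin-1-yl on a saturated chain carbon bound to an aromatic carbon, lies within the scatter and sits at a different place. Going by the values given here, no measured pair changes the chlorophenyl group, so that step bears on this change only loosely and no direction can be read from the data. The estimated step is a 1.0-fold lower number from compound 1 to compound 4 (0.00 log units; within the scatter) in this assay and is expected to stay within the scatter. Compound 4 is expected at 2800 nM within an estimated range of 1300 nM to 6000 nM in this measurement.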

Compound 4, half-maximal inhibitory concentration: 3330 nM
Beside the measured number, compound 4's estimate is 1.2-fold (0.08 log units) below it; measured number inside the range.
By their numbers in this assay, from the lowest: compounds 3, 1, 2 and 4 (each within the scatter of the next).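

In this assay, for the compounds shown here, the change from 3-chlorophenyl to 2-chlorophenyl on a saturated chain carbon bound to an aromatic nitrogen gives a 1.2-fold higher number from compound 1 to compound 4 (0.07 log units; within the scatter) and is the first measured step at this place. The earlier step changed only the amine on a saturated chain carbon bound to an aromatic carbon, whereas this pair shows that 3-chlorobenzyl and 2-chlorobenzyl cannot be told apart in this read-out. No further evidence bears on this result.

Going by these compounds alone, with only one pair at this place, it remains open whether the same holds when diethylamino stands in place of 4-methylpiperidin-1-yl. Also open, on these data alone, is whether a benzyl without chlorine, or one carrying methoxy or a nitrile in place of the chlorine, would stay within the scatter of compound 1.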